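Swapping a ring for a branched chain on the ring nitrogen

The compounds below may be only part of what the source reports. "The series", "measured", "known", "first", "only" and "open" are said of these compounds alone.

Compound 1 `NC(=O)c1c(NC(=O)Nc2ccc(Cl)cc2)sc2c1CCN(C1CCOCC1)C2` is one of three related compounds tested in a functional assay (strain AB) with Danio rerio as the target, read by microscopy, with a stated time of 1 h; on this read-out higher numbers stand for an effect only at larger amounts of compound and lower numbers for an effect already at smaller amounts. In this assay compound 1 gives 2830 nM. Compound 3 `CCN1CCc2c(sc(NC(=O)Nc3ccc(Br)cc3)c2C(N)=O)C1` is very close to it: in this assay compound 3 gives 3130 nM, and the two values lie within the usual scatter of each other. Compound 2 `CC(C)(C)C[N+]1(C)CCc2c(sc(NC(=O)Nc3ccc(Cl)cc3)c2C(N)=O)C1` stands apart: in this assay compound 2 gives 290 nM, a number well below that of compound 1 and beyond the scatter. Compound 2 carries a neopentyl group, along with a methyl, on a charged nitrogen in the ring, while compound 1 carries an oxan-4-yl group there.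

Compound 4 `CC(C)(C)CN1CCc2c(sc(NC(=O)Nc3ccc(Cl)cc3)c2C(N)=O)C1` has not yet been measured. It differs from compound 1 in one place: neopentyl in place of oxan-4-yl on an amine nitrogen in a ring. Within the data shown here, no single-change step between measured compounds covers this swap, so the expectation rests on what compound 1 and compound 2 show. Among the measured compounds shown here, since compound 2, the only neopentyl-bearing compound, gives 290 nM, the number for compound 4 is expected to fall below that of compound 1, by a step beyond the scatter, estimated as a 4.4-fold lower number from compound 1 to compound 4 (0.64 log units; beyond the scatter). For compound 4 in this assay the estimated value is 650 nM, with a likely range from 220 nM to 2000 nM.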

Compound 4, half-maximal effective concentration: 5560 nM
For compound 4 the middle estimate is 8.6-fold (0.93 log units) below the measured one; measured number outside the range, above it.
By their numbers in this assay, from the lowest: compound 2; then compounds 1, 3 and 4 (each within the scatter of the next).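

In this assay the swap of oxan-4-yl for neopentyl on an amine nitrogen in a ring gives a 2.0-fold higher number from compound 1 to compound 4 (0.29 log units; within the scatter), so at this position the two groups cannot be told apart, even though one is a ring holding an oxygen and the other an open, branched chain. Neopentyl alone therefore does not bring the low number: compound 4 gives 5560 nM with neopentyl on a neutral ring nitrogen, while compound 2, which has the same neopentyl together with a methyl on a charged nitrogen, gives 290 nM. No measurement here explains why these values fall as they do.

Still open, going by these compounds, is whether the low number of compound 2 is tied to neopentyl or would also appear with a methyl and another group, such as oxan-4-yl or benzyl, on the charged nitrogen. On these data alone, it is equally open whether a group of a different kind on the neutral nitrogen, such as a hydroxyethyl chain or a longer alkyl chain, would move the number beyond the scatter.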